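The compounds below may be only part of what the source reports. "The series", "measured", "known", "first", "only" and "open" are said of these compounds alone.

- Compound 1 `O=C(NCc1ccccc1)Oc1ccc(Cl)cc1C(=O)Nc1ccc(C(F)(F)F)cc1` in an ADME assay on HepG2 cells (Homo sapiens) for cytotoxicity, read by MTT assay; a higher number here means a weaker inhibitor, a lower number a stronger inhibitor: > 125000 nM (a limit of the assay)
- Compound 2 `O=C(Nc1ccccc1)Oc1ccc(Cl)cc1C(=O)Nc1ccc(C(F)(F)F)cc1` in this assay: 9800 nM

Among the measured compounds shown here, compound 2 holds the only actual number so far, 9800 nM, in this assay. Compound 1 has only a limit, > 125000 nM, and not a number.

Compound 3 `O=C(NC1CCCCC1)Oc1ccc(Cl)cc1C(=O)Nc1ccc(C(F)(F)F)cc1` has not yet been measured. It carries cyclohexyl in place of phenyl on an amide-type nitrogen, so the six-membered ring of carbon only is now non-aromatic.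

For the measured compounds named here, one measured step bears on this nitrogen: an at least 12-fold lower number from compound 1 to compound 2 (1.10 log units; beyond the scatter), a large step with phenyl in place of benzyl. Its size rests on (the limit of > 125000 nM in this assay, at which 1 of the 2 values shown sits). Phenyl therefore sits at the lower end of the only comparison available, although cyclohexyl itself has not been tested against either group. A sizeable move to a higher number in this assay is expected, probably smaller than the measured step and possibly reaching the limit of the assay.

The estimated change is a 4.1-fold higher number from compound 2 to compound 3 (0.61 log units; beyond the scatter). For compound 3 the expected value is 40000 nM, with an estimated range of 12000 nM to 125000 nM.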

Compound 3, half-maximal inhibitory concentration: > 125000 nM
Compound 3 ended at the assay's limit; the forecaster's own chance of this, stated with the estimate: 25%; middle value at least 3.1-fold (0.49 log units) from the limit.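

In this assay, putting cyclohexyl in place of phenyl on the amide-type nitrogen gives an at least 12-fold higher number from compound 2 to compound 3 (1.10 log units; beyond the scatter), although the two groups have the same count of heavy atoms, all carbon, and neither carries a hydrogen-bond donor or acceptor. Compound 3 stands at > 125000 nM, which is a limit of the assay and not a number, so among the three groups shown at this position, only the phenyl of compound 2 gives a measured value, and both the benzyl and the cyclohexyl neighbours of that result end at the limit. The step between compound 1 and compound 3 cannot be read, and the two steps around compound 2 give only the smallest size they can have, because of where these values sit: the limit of > 125000 nM in this assay, at which 2 of the 3 values shown sit.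

Benzyl and cyclohexyl therefore cannot be ordered against each other, and how far either lies from phenyl stays unknown. As far as these compounds go, it also stays open whether the lower number belongs to phenyl alone or extends to other aromatic rings on this nitrogen, such as a pyridyl or a chlorophenyl, or to a short chain such as ethyl.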